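The source may report more compounds than this note shows. Statements on the series, on what has been measured and on what is new or still open speak of the compounds shown alone.

Working notes on the series. In a functional assay on A549 cells (Homo sapiens) for cytotoxicity, read by MTT assay, with a stated time of 72 h (a lower number here means a stronger inhibitor, a higher number a weaker inhibitor), compound 1 (`COc1ccc(S(=O)(=O)c2nc3ccccc3nc2N2CCCC2)cc1`) gives a limit (> 50000 nM) and not a number, so its standing is known only as that limit. Compound 2 (`O=S(=O)(c1ccc(Br)cc1)c1nc2ccccc2nc1N1CCCC1`) also gives a limit (> 50000 nM) and not a number. Both compounds sit at the same limit (the limit of > 50000 nM in this assay, at which 2 of the 2 values shown sit).

Compound 3 (`O=S(=O)(c1ccc(F)cc1)c1nc2ccccc2nc1N1CCCC1`) is the next step from compound 1: fluoro in place of methoxy on an aromatic carbon, para to a large group, which turns 4-methoxyphenyl into 4-fluorophenyl (fluoro in place of methoxy on an aromatic carbon). Within the data shown here, the one measured step at this carbon is the bromo in place of methoxy change (a step that the two limits leave unreadable from compound 1 to compound 2), and it has no readable size. Among the measured compounds shown here, no step beyond the scatter is therefore expected in this assay, and no direction can be assigned, since the only comparison at this carbon (a step that the two limits leave unreadable from compound 1 to compound 2) shows no measurable change.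

The expected step is small (a step that the limit leaves unreadable from compound 1 to compound 3). For compound 3 the estimated value is 60000 nM, with an expected range from 25000 nM to 120000 nM, and a report as a limit is the likeliest outcome.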

Compound 3, half-maximal inhibitory concentration: 31100 nM
The estimate for compound 3 lay 1.9-fold (0.29 log units) above the measured number; the range from low to high includes it.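

Among these compounds, at this aromatic carbon, para to a large group, fluoro gives the first number rather than a limit, which shows that a change at this position alone can bring a value inside the measurable range of this assay. The result reads an at least 1.6-fold lower number from compound 1 to compound 3 (0.20 log units; that floor lies within the scatter), and likewise an at least 1.6-fold lower number from compound 2 to compound 3 (0.20 log units; that floor lies within the scatter); each is only a floor on the step, not its size, and as both floors lie within the scatter, neither shows a real gain over the methoxy or bromo group. Most of what is known at this position in this assay therefore remains a limit rather than a number: the limit of > 50000 nM in this assay, at which 2 of the 3 values shown sit.

Still open, as far as these compounds go, is how far the value can move at this carbon, and whether a group such as an amine, a carboxylic acid or a nitrile would give a number or another limit. The three compounds shown also share one core and differ only at this carbon, so they leave open whether a change elsewhere on the core would move the value further.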